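Cyclopropylamine to hydroxylamine on the benzylic amine

A few compounds are considered here, and "the series" means these few. Any claim that something is new, unique, unknown or untested is made for them only; others in the source may bear on it.

Three compounds of the series have been run in an ADME assay on MT4 cells (Homo sapiens) for cytotoxicity, read by MTT assay, with a stated time of 5 days; a higher number here means that more compound is tolerated, a lower number that less compound is tolerated. Compound 1 `CCNC(c1ccnc(Nc2ccc(C#N)cc2)n1)c1ccccc1Cl` gives 39400 nM. Compound 2 `N#C/C=C/c1ccc(C(NC2CC2)c2ccnc(Nc3ccc(C#N)cc3)n2)cc1` gives 56100 nM. Compound 3 `CCCNC(c1ccc(C#N)cc1)c1ccnc(Nc2ccc(C#N)cc2)n1` gives 34900 nM. The three numbers lie within the scatter of one another, so compound 2 cannot be set apart from compound 1 or compound 3 in this assay; its number is simply one of three that sit close together.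

Compound 4 `N#C/C=C/c1ccc(C(NO)c2ccnc(Nc3ccc(C#N)cc3)n2)cc1` has not yet been measured. It differs from compound 2 in one place: hydroxy in place of cyclopropyl on an amine nitrogen. Nothing in the measured set isolates the effect of a change at the amine nitrogen, since compounds 1, 2 and 3 differ in several places at once.

Given that compounds 1, 2 and 3 all fall close together in this assay, compound 4 is expected to give a number of the same order, with the step from compound 2 to compound 4 estimated as a 1.1-fold lower number from compound 2 to compound 4 (0.05 log units; within the scatter), not beyond the scatter. The estimate for compound 4 is 50000 nM, with a range from 20000 nM to 150000 nM.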

Compound 4, half-maximal cytotoxic concentration: 161000 nM
Estimate against measurement, compound 4: 3.2-fold (0.51 log units) below; the measured number lies above the stated range.
By their numbers in this assay, from the lowest: compounds 3, 1 and 2 (each within the scatter of the next); then compound 4.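

Within the data shown here, the change from cyclopropyl to hydroxy on the amine nitrogen is the first single-place step, and in this assay it reads as a 2.9-fold higher number from compound 2 to compound 4 (0.46 log units; beyond the scatter) for this one pair. The amine nitrogen is therefore a place where one change moves the number, which compounds 1, 2 and 3 could not show while they differed in several places at once. Nothing at hand accounts for this step.

Among these compounds, only this single pair carries the change, so it remains open whether the step belongs to the arrival of hydroxy or the loss of cyclopropyl. Also open, from the compounds shown here alone, are how a methoxy group, an unsubstituted amine or a longer chain on the same nitrogen would read, and whether hydroxy gives a like step on the other side groups of compound 1 or compound 3.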